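The compounds below may be only part of what the source reports. "The series", "measured", "known", "first", "only" and "open" are said of these compounds alone.

In a functional assay on HepG2 cells (Homo sapiens) for antiproliferative activity, read by XTT assay, with a stated time of 72 h (a lower number here means a stronger inhibitor, a higher number a weaker inhibitor), three close analogues have been tested so far. Compound 1 `C#Cc1cn([C@@H]2O[C@H](CO)[C@@H](O)[C@H]2O)c2ncnc(NC)c12` reaches only a limit of the assay, giving > 15000 nM. Compound 2 `C#Cc1cn([C@@H]2O[C@H](CO)[C@@H](O)[C@H]2O)c2nc(C)nc(N)c12` likewise reaches only a limit, giving > 20000 nM. Compound 3 `Cc1nc(N)c2c(I)cn([C@@H]3O[C@H](CO)[C@@H](O)[C@H]3O)c2n1` gives 6310 nM in this assay. The change from compound 2 to compound 3 is iodo in place of ethynyl on an aromatic carbon and it produces an at least 3.1-fold lower number from compound 2 to compound 3 (0.50 log units; beyond the scatter). The difference between the cores of compound 1 and compound 2 is not broken down here. Compound 4 `CNc1ncnc2c1c(I)cn2[C@@H]1O[C@H](CO)[C@@H](O)[C@H]1O` carries the same change relative to compound 1, namely (iodo in place of ethynyl on an aromatic carbon). Because compound 1 sits at the limit of > 15000 nM in this assay, at which 1 of the 3 values shown sits, the starting point is itself uncertain. The expected step is an at least 2.5-fold lower number from compound 1 to compound 4 (0.39 log units; beyond the scatter), resting on the measured step of an at least 3.1-fold lower number from compound 2 to compound 3 (0.50 log units; beyond the scatter). Compound 4 is therefore estimated at 6000 nM in this assay, with a plausible range from 2000 nM to 20000 nM.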

Compound 4, half-maximal inhibitory concentration: > 20000 nM
Compound 4: only a limit was reported; the forecaster's own chance of this, stated with the estimate: 30%; middle value at least 3.3-fold (0.52 log units) from the limit.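

In this assay compound 4 gives only a limit (> 20000 nM). Going by these compounds alone, compound 1 is also only a limit (> 15000 nM), so no step between the two can be read. The compounds shown leave open whether iodo in place of ethynyl changes the number at all on the core of compound 1.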